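From a Urea-Type Tail to a Carboxymethyl Tail

A few compounds are considered here, and "the series" means these few. Any claim that something is new, unique, unknown or untested is made for them only; others in the source may bear on it.

Of the compounds shown here, three sharing one core have been measured in a functional assay (aorta) with Rattus norvegicus as the target; on this read-out lower numbers stand for an effect already at smaller amounts and higher numbers for an effect only at larger amounts of compound. Compound 1 `COc1ccc(-c2nc(CNC(=O)CSc3ccccc3)sc2-c2ccc(OC)cc2)cc1` gives 4.2 uM. Compound 2 `COc1ccc(-c2nc(CNC(=O)N3CCOCC3)sc2-c2ccc(OC)cc2)cc1` gives 12 uM, and compound 3 `CNC(=O)NCc1nc(-c2ccc(OC)cc2)c(-c2ccc(OC)cc2)s1` gives 15 uM, the highest of the three numbers. The step of a 2.9-fold higher number from compound 1 to compound 2 (0.46 log units; beyond the scatter) and the step of a 3.6-fold higher number from compound 1 to compound 3 (0.55 log units; beyond the scatter) were both modest, while the step of a 1.3-fold higher number from compound 2 to compound 3 (0.10 log units; within the scatter) stayed within the scatter. Compound 4 `COc1ccc(-c2nc(CCC(=O)O)sc2-c2ccc(OC)cc2)cc1` differs from compound 3 in one place: carboxymethyl in place of (methylcarbamoyl)amino on a saturated chain carbon bound to an aromatic carbon. Within the data shown here, none of the measured steps exchanges a group of this kind; each of them only swaps the group attached to a carbonyl carbon. The measured steps therefore show only that reshaping the tail of this core has so far moved the number in this assay modestly at most. For compound 4 a step of a 1.3-fold higher number from compound 3 to compound 4 (0.12 log units; within the scatter) is expected. Nothing measured points to a large shift in either direction, and the uncertainty is wide. Compound 4 is therefore estimated at 20 uM, with a range from 6 uM to 60 uM.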

Compound 4, concentration for half-maximal effect: > 100 uM
Compound 4 ended at the assay's limit; the forecaster's own chance of this, stated with the estimate: 10%; at least 5.0-fold (0.69 log units) between middle value and limit.
By their numbers in this assay, from the lowest: compound 1; then compounds 2 and 3 (each within the scatter of the next). At a limit, above all of these: compound 4.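

Compound 4 stands at a limit of this assay, so its value is a limit and not a number: the limit of > 100 uM in this assay, at which 1 of the 4 values shown sits.

Swaps on the carbonyl carbon had moved the number modestly at most, whereas changing the group on a saturated chain carbon bound to an aromatic carbon gives larger steps: an at least 6.6-fold higher number from compound 3 to compound 4 (0.82 log units; beyond the scatter), an at least 8.3-fold higher number from compound 2 to compound 4 (0.92 log units; beyond the scatter) and an at least 23-fold higher number from compound 1 to compound 4 (1.37 log units; beyond the scatter). Among these four compounds, the three with a nitrogen-linked carbonyl tail give readable numbers, while the one with carboxymethyl does not, so this position is far less forgiving of this exchange than of the earlier swaps.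

As far as these compounds go, how far past the limit compound 4 lies stays unknown. The compounds shown also cannot separate the effect of the carboxylic acid from that of losing the tail's nitrogen, a question that a methyl ester on the same chain or a primary amine at its end could address.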